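The compounds below may be only part of what the source reports. "The series", "measured", "known", "first", "only" and "open" are said of these compounds alone.

Compound 1 `O[C@@H]1[C@@H](OCc2ccccc2)[C@H](O)[C@@H](COCc2ccccc2)O[C@H]1Cc1ccccc1` belongs to a small set of protected sugar derivatives, and in a functional assay on HL-60 cells (Homo sapiens) for antiproliferative activity, read by MTT assay (on this read-out lower numbers stand for stronger inhibition and higher numbers for weaker inhibition), compound 1 gives 35300 nM. Compound 2 `CCC[C@H]1O[C@H](COCc2ccccc2)[C@H](OCc2ccccc2)[C@H](OCc2ccccc2)[C@H]1O` is reported in this assay only as "not active" (no number reported), with no single number attached, and compound 3 `CC(C)C[C@H]1O[C@H](COCc2ccccc2)[C@H](OCc2ccccc2)[C@H](OCc2ccccc2)[C@H]1O` is likewise reported there as "not active" (no number reported). So compound 2 stands without a numerical value, one of two such entries in the set, and the only number in the set, that of compound 1, is a weak one. Compound 4 `CCC[C@H]1O[C@H](COCc2ccccc2)[C@@H](OCc2ccccc2)[C@H](OCc2ccccc2)[C@H]1O` has not yet been measured; it differs from compound 2 as follows: the two compounds have the same atoms and bonds and differ only in configuration as drawn: 1 of 5 stereo elements differ; a stereocentre at a saturated ring carbon is drawn S in compound 2 and R in compound 4. For the measured compounds named here, no measured pair shows what this change does, so no step size can be taken from the data, and a result near the inactive entries seems most plausible. Compound 4 is expected in this assay to give about 60000 nM, estimated between 20000 nM and 200000 nM, with a considerable chance that no number at all is reported.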

Compound 4, half-maximal inhibitory concentration: 28200 nM
The estimate for compound 4 lay 2.1-fold (0.33 log units) above the measured number, and the stated range covers the measured number.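

No step can be read from compound 2 to compound 4, as compound 2 is reported only as "not active", without a number. The compounds shown leave open how large an effect that single stereocentre has in this assay.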